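A few compounds are considered here, and "the series" means these few. Any claim that something is new, unique, unknown or untested is made for them only; others in the source may bear on it.

In a functional assay on MCF7 cells (Homo sapiens) for cytotoxicity, read by MTT assay, with a stated time of 72 h (a higher number here means a weaker inhibitor, a lower number a stronger inhibitor), compound 1 `CNC(=O)c1cc(Oc2ccc(C(=O)/C=C/c3ccc(OC)c(OC)c3OC)cc2)ccn1` gives 2910 nM as its half-maximal inhibitory concentration. From the compounds shown here alone, compound 2 `CNC(=O)c1cc(Oc2ccc(C(=O)/C=C/c3ccc(Br)cc3)cc2)ccn1` gives > 50000 nM in this assay and that entry is a limit, not a number, so its exact place on the scale is unknown. Compound 3 `CNC(=O)c1cc(Oc2ccc(C(=O)/C=C/c3ccccc3)cc2)ccn1` has hydrogen in place of bromo on an aromatic carbon and so carries phenyl where compound 2 carries 4-bromophenyl. Going by the values given here, no measured pair shows this change alone, so the size of the step has to be estimated. A modest move towards stronger inhibition is expected in this assay and this rests on compound 1, whose 2910 nM shows that the shared core can give a measurable value. The expected change is an at least 2.5-fold lower number from compound 2 to compound 3 (0.39 log units; beyond the scatter) as a rough estimate. For compound 3 the estimated value is 20000 nM with an expected range from 6000 nM to 50000 nM in this assay.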

Compound 3, half-maximal inhibitory concentration: 5960 nM
Compound 3: the middle estimate sits 3.4-fold (0.53 log units) above what was measured, outside the stated range (below it).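

In this assay, going by these compounds alone, the swap of bromo for hydrogen, on an aromatic carbon para to a large group, gives an at least 8.3-fold lower number from compound 2 to compound 3 (0.92 log units; beyond the scatter) and is the first single change that can be read here. At this position, then, bromo and hydrogen are not interchangeable, and the plain phenyl compound gives a measurable value. From the compounds shown here alone, the true size of the step stays unknown, since the entry for compound 2 is a limit and not a number, so the step sets only a minimum: the limit of > 50000 nM in this assay, at which 1 of the 3 values shown sits.

One swap cannot tell whether the loss belongs to bromo alone or would follow other groups at this place. Going by these compounds, whether chloro, a methyl group, an amine or a carboxylic acid there would land nearer compound 3 or compound 2 remains open.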